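The source may report more compounds than this note shows. Statements on the series, on what has been measured and on what is new or still open speak of the compounds shown alone.

Of the compounds shown here, three have so far been measured in a functional assay on HTB-54 cells (Homo sapiens) for cytotoxicity, read by MTT assay, with a stated time of 72 h; a higher number here means a weaker inhibitor of growth, a lower number a stronger inhibitor of growth. Compound 1 `CCCCC[Se]c1nc(N)c2ccccc2n1` gives 84000 nM, compound 2 `COc1ccc(CNc2nc([SeH])nc3ccccc23)cc1` gives 60900 nM, and compound 3 `CSc1nc(NCCCCCO)c2ccccc2n1` gives 71400 nM. Compound 2 has the lowest of the three numbers, yet its gaps to compound 3 and to compound 1 both fall within the scatter, so the three cannot be told apart. Compound 4 `COc1ccc(CNc2nc(SC)nc3ccccc23)cc1` has not yet been measured. It differs from compound 2 in one place: a group of 2 heavy atoms (1 carbon, 1 sulfur; no ring) in place of one selenium atom, on an aromatic carbon. No step beyond the scatter is expected in either direction, because compound 3, which carries the same methylsulfanyl group, gives 71400 nM. The expected step is a 1.1-fold higher number from compound 2 to compound 4 (0.06 log units; within the scatter). Compound 4 is thus estimated at 70000 nM, within 30000 nM to 160000 nM.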

Compound 4, concentration for total growth inhibition: > 100000 nM
Compound 4 gave a limit, no number; the forecaster's own chance of this, stated with the estimate: 10%; middle value at least 1.4-fold (0.15 log units) from the limit.
By their numbers in this assay, from the lowest: compounds 2, 3 and 1 (each within the scatter of the next). At a limit, above all of these: compound 4.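

In this assay compound 4 gives > 100000 nM, which is a limit of the assay and not a number. Placing methylsulfanyl in place of the selenium atom, on the aromatic carbon between two ring nitrogen atoms, gives an at least 1.6-fold higher number from compound 2 to compound 4 (0.21 log units; that floor lies within the scatter). Going by these compounds, this first direct comparison at this position therefore shows no firm loss of growth inhibition, and the true size of the step stays unknown.

Open, on these data alone, is whether the exchange of selenium for sulfur or the added methyl carbon matters more. A methylselanyl group or a free thiol on the core of compound 2 would separate the two.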